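Replacing 3-(trifluoromethyl)phenyl with 2,3-dichlorophenyl in compound 1

A few compounds are considered here, and "the series" means these few. Any claim that something is new, unique, unknown or untested is made for them only; others in the source may bear on it.

Measured so far:
compound 1 `N#Cc1ccc(Nc2nc(Oc3ccnc4ccccc34)nc(N3CCN(c4cccc(C(F)(F)F)c4)CC3)n2)cc1C(F)(F)F`: 74100 nM
compound 2 `N#Cc1ccc(Nc2nc(Oc3ccnc4ccccc34)nc(N3CCC(Cc4ccccc4)CC3)n2)cc1C(F)(F)F`: > 100000 nM, a limit of the assay
compound 3 `N#Cc1ccc(Nc2nc(Oc3ccnc4ccccc34)nc(N3CCCCC3)n2)cc1C(F)(F)F`: > 100000 nM, a limit of the assay

In a functional assay on DU-145 cells (Homo sapiens) for cytotoxicity, read by sulforhodamine B assay, with a stated time of 48 h (a higher number here means a weaker inhibitor of growth, a lower number a stronger inhibitor of growth), compound 1 gives 74100 nM. Among the measured compounds shown here, this is the only number in the set; the other two values sit at the limit of > 100000 nM in this assay, at which 2 of the 3 values shown sit. For the measured compounds named here, the one step between measured compounds, a step that the two limits leave unreadable from compound 2 to compound 3, is unreadable. Going by the values given here, no measured step bears on the change to compound 4 `N#Cc1ccc(Nc2nc(Oc3ccnc4ccccc34)nc(N3CCN(c4cccc(Cl)c4Cl)CC3)n2)cc1C(F)(F)F`, which carries 2,3-dichlorophenyl in place of 3-(trifluoromethyl)phenyl on an amine nitrogen in a ring. With nothing to read from, the expectation for compound 4 is no step beyond the scatter, that is a 1.1-fold higher number from compound 1 to compound 4 (0.03 log units; within the scatter). Compound 4 is therefore estimated at 80000 nM, with a range from 30000 nM to 200000 nM, and a real chance that this assay again reports only a limit.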

Compound 4, concentration for total growth inhibition: > 100000 nM
Compound 4 was reported as a limit; the forecaster's own chance of this, stated with the estimate: 40%; middle value at least 1.2-fold (0.09 log units) away from the limit.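

In this assay, 2,3-dichlorophenyl in place of 3-(trifluoromethyl)phenyl on the amine nitrogen in the ring gives an at least 1.3-fold higher number from compound 1 to compound 4 (0.13 log units; that floor lies within the scatter), so this change has no readable size and no shift beyond the scatter can be claimed. Compound 4 gives > 100000 nM, which is a limit of the assay. Any readable number at this position still rests on compound 1 alone, and the series sits mostly at the limit: the limit of > 100000 nM in this assay, at which 3 of the 4 values shown sit.

From the compounds shown here alone, whether an unsubstituted phenyl, or a phenyl carrying a methoxy group or an amine, on that nitrogen would give a readable number stays open.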